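Aryl substituent changes on a bis-benzylidene core

This account rests on a few compounds, and the source may have more. Where it says the series, first, only, none or still open, it means among the compounds named here.

Measured compounds in a functional assay on A549 cells (Homo sapiens) for cytotoxicity, read by CCK-8 assay, with a stated time of 72 h; on this read-out lower numbers stand for stronger inhibition and higher numbers for weaker inhibition:
compound 1 `C=CCn1c(=O)/c(=C\c2ccccc2Cl)[nH]c(=O)/c1=C\c1ccccc1OC`: 5300 nM
compound 2 `C=CCn1c(=O)/c(=C\c2ccccc2OC)[nH]c(=O)/c1=C\c1ccccc1OC`: 22400 nM
compound 3 `C=CCn1c(=O)/c(=C\c2ccccc2C(F)(F)F)[nH]c(=O)/c1=C\c1ccccc1OC`: 7000 nM

Among these three numbers compound 3 stands second highest. Its nearest neighbour is compound 1, the step of a 1.3-fold higher number from compound 1 to compound 3 (0.12 log units; within the scatter) lying within the scatter, so the two are not distinguishable on this read-out. Compound 2 is furthest off: the step of a 3.2-fold lower number from compound 2 to compound 3 (0.51 log units; beyond the scatter) is a modest one beyond the scatter, and the parallel step a 4.2-fold higher number from compound 1 to compound 2 (0.63 log units; beyond the scatter) points the same way, methoxy giving the higher number against either chloro or trifluoromethyl.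

Compound 4 `C=CCn1c(=O)/c(=C\c2cccc(C)c2)[nH]c(=O)/c1=C\c1ccccc1OC` carries the change (3-methylphenyl in place of 2-(trifluoromethyl)phenyl on a double-bonded chain carbon bound to an aromatic carbon). Within the data shown here, this is not a single-substituent swap of the kind the three measured steps describe; it replaces the whole substituted ring with one bearing a methyl in a different arrangement, so no measured step bears on it directly. Among the measured compounds shown here, the only guide is that the three measured rings span a narrow band of numbers, with one variant clearly weaker.

On that basis the expected step of a 1.1-fold higher number from compound 3 to compound 4 (0.06 log units; within the scatter) is small, with wide uncertainty in either direction. Compound 4 is estimated at 8000 nM, range 2500 nM to 26000 nM.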

Compound 4, half-maximal inhibitory concentration: 22700 nM
Compound 4: the middle estimate sits 2.8-fold (0.45 log units) below what was measured, within the range that was stated.
By their numbers in this assay, from the lowest: compounds 1 and 3 (each within the scatter of the next); then compounds 2 and 4 (each within the scatter of the next).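

On this double-bonded chain carbon, 3-methylphenyl does not stay with the lower pair in this assay: the change gives a 3.2-fold higher number from compound 3 to compound 4 (0.51 log units; beyond the scatter) and, against 2-chlorophenyl, a 4.3-fold higher number from compound 1 to compound 4 (0.63 log units; beyond the scatter) as well, both steps beyond the scatter. Against 2-methoxyphenyl the change gives a 1.0-fold higher number from compound 2 to compound 4 (0.01 log units; within the scatter) and that step lies within the scatter, so the higher numbers are no longer tied to methoxy alone, and the four compounds fall into two pairs, compounds 1 and 3 against compounds 2 and 4, with none going against that split. Nothing at hand accounts for this split.

Going by these compounds, compound 4 changes both the group and where it sits on the ring, so whether its higher number goes with the methyl itself or with that placement stays open. Also open, on these data alone, is what an unsubstituted phenyl, or a ring bearing an amine or a carboxylic acid, would give on this chain carbon with the rest of the core unchanged.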